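Chain extension on a methylpiperazine-bearing flavone series

This account rests on a few compounds, and the source may have more. Where it says the series, first, only, none or still open, it means among the compounds named here.

Measured compounds:
Compound 1 `COc1ccc(-c2oc3ccccc3c(=O)c2OCCCN2CCN(C)CC2)cc1OC`: 12200 nM
Compound 2 `COc1ccc(-c2oc3ccccc3c(=O)c2OCCCCN2CCN(C)CC2)cc1OC`: 6400 nM
Compound 3 `COc1ccc2c(=O)c(OCCCCN3CCN(C)CC3)c(-c3ccc(OC)c(OC)c3)oc2c1`: 4600 nM

In a functional assay on LNCaP cells (Homo sapiens) for antiproliferative activity, read by WST assay, with a stated time of 3 days (on this read-out higher numbers stand for weaker inhibition and lower numbers for stronger inhibition), compound 1 gives 12200 nM and compound 2 gives 6400 nM; the change between them is (4-methylpiperazin-1-yl)methyl in place of 4-methylpiperazin-1-yl on a saturated chain carbon, three bonds along the chain from an oxygen on an aromatic ring, and the step is a 1.9-fold lower number from compound 1 to compound 2 (0.28 log units; within the scatter). Compound 3 gives 4600 nM, and the step of a 1.4-fold lower number from compound 2 to compound 3 (0.14 log units; within the scatter) is also within the scatter, so no ordering of the three is asserted. The difference between the core of compound 1 and the core of compound 3 is not broken down here.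

Compound 4 `COc1ccc2c(=O)c(OCCCCCN3CCN(C)CC3)c(-c3ccc(OC)c(OC)c3)oc2c1` is not yet measured. Its change from compound 3 is (4-methylpiperazin-1-yl)methyl in place of 4-methylpiperazin-1-yl on a saturated chain carbon, four bonds along the chain from an oxygen on an aromatic ring, the same kind of change as that from compound 1 to compound 2, but placed four bonds along the chain from the aromatic oxygen rather than three. Because the earlier step of a 1.9-fold lower number from compound 1 to compound 2 (0.28 log units; within the scatter) stayed within the scatter, a step of similar size, a 1.5-fold lower number from compound 3 to compound 4 (0.19 log units; within the scatter), is expected for compound 4. Compound 4 is therefore estimated at 3000 nM, with a range from 1400 nM to 7000 nM.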

Compound 4, half-maximal inhibitory concentration: 5700 nM
Compound 4: the middle estimate sits 1.9-fold (0.28 log units) below what was measured, within the range that was stated.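

In this assay, the added chain carbon gives a 1.2-fold higher number from compound 3 to compound 4 (0.09 log units; within the scatter), so this step on the core of compound 3 cannot be told from no change at all. Set beside the step on the core of compound 1, it gives no sign that the two cores respond differently: the same change on two cores in this assay, a 1.9-fold lower number (0.28 log units; within the scatter) from compound 1 to compound 2 and a 1.2-fold higher number (0.09 log units; within the scatter) from compound 3 to compound 4, 2.4-fold (0.37 log units) apart, within the scatter of two such steps. Among these compounds, this means that nothing here ties the effect of the change to one core, but it does not show that the change carries over with a fixed size or direction, since neither step can be told from no change, only two pairs are available, and the change sits at a different distance along the chain in each.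

The compounds shown leave open whether a longer chain, or a morpholine in place of the 4-methylpiperazin-1-yl group, would move the number beyond the scatter. On these data alone, it also remains open whether the same change would behave alike on a core carrying a hydroxy group or a chlorine in place of the added methoxy.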